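A Hydroxynaphthyl Hydrazone Replaces the Nitrophenyl Group

The source may hold more compounds than are shown below. What is called first, only, known or untested is meant among the compounds shown, and "the series" means these compounds.

Of the compounds shown here, three sharing one core have been tested in a functional assay on ECa-109 cells (Homo sapiens) for antiproliferative activity, read by MTT assay, with a stated time of 72 h; a lower number here means a stronger inhibitor, a higher number a weaker inhibitor. Compound 1 `CCCSc1nc(N/N=C/c2ccc(N(C)C)cc2)c2nnn(Cc3ccccc3)c2n1` gives 20000 nM. Compound 2 `CCCSc1nc(N/N=C/c2cccs2)c2nnn(Cc3ccccc3)c2n1` reaches only the assay limit, > 64000 nM. Compound 3 `CCCSc1nc(N/N=C/c2ccc([N+](=O)[O-])cc2)c2nnn(Cc3ccccc3)c2n1` gives 6640 nM, the lowest of the two measured numbers and the strongest result; the steps of a 3.0-fold lower number from compound 1 to compound 3 (0.48 log units; beyond the scatter) and an at least 9.6-fold lower number from compound 2 to compound 3 (0.98 log units; beyond the scatter) show that the group on the carbon with a double bond to nitrogen moves the number beyond the scatter. Compound 4 `CCCSc1nc(N/N=C/c2c(O)ccc3ccccc23)c2nnn(Cc3ccccc3)c2n1` is not yet measured and differs from compound 3 by 2-hydroxynaphthalen-1-yl in place of 4-nitrophenyl on a carbon with a double bond to nitrogen. Within the data shown here, no measured step matches this change, so the expectation rests only on both known steps having shifted the number when that group was exchanged. Compound 4 is therefore expected to be somewhat weaker, a 2.3-fold higher number from compound 3 to compound 4 (0.35 log units; beyond the scatter), with an estimate of 15000 nM, ranging from 4000 nM to 60000 nM.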

Compound 4, half-maximal inhibitory concentration: 9290 nM
For compound 4 the middle estimate is 1.6-fold (0.21 log units) above the measured one, within the range that was stated.
By their numbers in this assay, from the lowest: compounds 3 and 4 (each within the scatter of the next); then compound 1. At a limit, above all of these: compound 2.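

Exchanging 4-nitrophenyl for 2-hydroxynaphthalen-1-yl, which brings a second aromatic ring and a hydrogen-bond donor and removes the nitro group, gives no readable change in this assay: a 1.4-fold higher number from compound 3 to compound 4 (0.15 log units; within the scatter). This position therefore tolerates a larger group without nitro, and the gap to the dimethylamino compound remains, with a 2.2-fold lower number from compound 1 to compound 4 (0.33 log units; beyond the scatter). Compound 2 is known only as a limit, so an at least 6.8-fold lower number from compound 2 to compound 4 (0.83 log units; beyond the scatter) gives a bound rather than an exact size.

As far as these compounds go, whether the hydroxyl or the second ring of compound 4 matters stays open. An unsubstituted naphthyl and a hydroxyphenyl group at this position would separate the two.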